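Chloro for fluoro on the aryl urea of compound 2

This account rests on a few compounds, and the source may have more. Where it says the series, first, only, none or still open, it means among the compounds named here.

Measured compounds:
compound 1, `CN(C)CCCNc1nc(-c2ccc(NC(=O)Nc3ccc(Cl)cc3)cc2)nc2c(Cl)c(Cl)sc12`, 330 nM
compound 2, `CN(C)CCNc1nc(-c2ccc(NC(=O)Nc3ccc(F)cc3)cc2)nc2c(Cl)c(Cl)sc12`, 890 nM

In a functional assay on HT-29 cells (Homo sapiens) for cytotoxicity, read by MTT assay, with a stated time of 72 h (on this read-out higher numbers stand for weaker inhibition and lower numbers for stronger inhibition), compound 2 gives the highest of the two numbers, and its nearest neighbour is compound 1, whose number is lower by more than the scatter. The two differ in two places, so their gap cannot be assigned to either change alone. Compound 3, `CN(C)CCNc1nc(-c2ccc(NC(=O)Nc3ccc(Cl)cc3)cc2)nc2c(Cl)c(Cl)sc12`, keeps the shorter chain of compound 2 and carries chloro in place of fluoro on an aromatic carbon, placing it one change away from each measured compound. For the measured compounds named here, no measured step isolates this change, so the expectation rests on compound 1 and compound 2 together. Compound 3 is expected to move modestly toward the lower number, a step of a 1.6-fold lower number from compound 2 to compound 3 (0.21 log units; within the scatter) in this assay, though a result within the scatter would not be surprising. The estimate for compound 3 is 550 nM, with a range from 250 nM to 1200 nM.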

Compound 3, half-maximal inhibitory concentration: 460 nM
Compound 3: middle estimate off by 1.2-fold (0.08 log units), on the high side; low and high end bracket the measured number.
By their numbers in this assay, from the lowest: compounds 1, 3 and 2 (each within the scatter of the next, the first and the last beyond it).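

In this assay, 4-fluorophenyl to 4-chlorophenyl on the urea can now be read as a single change, and it gives a 1.9-fold lower number from compound 2 to compound 3 (0.29 log units; within the scatter). The chain can also be read alone: dimethylamino in place of (dimethylamino)methyl gives a 1.4-fold higher number from compound 1 to compound 3 (0.14 log units; within the scatter), so neither single step stands clear of the scatter, although compound 1 and compound 2, which differ in both places, lie beyond it. No measurement is available that would explain either step.

The compounds shown leave open whether a bromo or methoxy group in this position on the aryl urea would stand apart from fluoro and chloro. They also leave open whether a longer chain, or a morpholine in place of the dimethylamino end, would do so.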